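The compounds below may be only part of what the source reports. "The series", "measured", "known", "first", "only" and "open" are said of these compounds alone.

The measured compounds:
compound 1, `OCCCNc1nc(-c2ccccc2)nc2c1nnn2Cc1ccccc1`: in an assay on isolated protein for binding affinity to adenosine receptor A1 (Bos taurus) (a lower number here means a stronger inhibitor, a higher number a weaker inhibitor), compound 1 gives 21400000 nM
compound 2, `c1ccc(Cn2nnc3c(NC4CC4)nc(-c4ccccc4)nc32)cc1`: compound 2 gives 11000000 nM
compound 3, `c1ccc(Cn2nnc3c(NC4CCCC4)nc(-c4ccccc4)nc32)cc1`: compound 3 gives 11000000 nM

All three compounds share one core and differ only in the group on a nitrogen on an aromatic ring. Compound 3 stands level with compound 2 at the digits shown, and its distance to compound 1 is small: a 1.9-fold lower number from compound 1 to compound 3 (0.29 log units; within the scatter). Every change at this nitrogen so far has stayed inside the scatter: a 1.9-fold lower number from compound 1 to compound 2 (0.29 log units; within the scatter), and no change at the digits printed from compound 2 to compound 3 (within the scatter).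

Compound 4, `CCNc1nc(-c2ccccc2)nc2c1nnn2Cc1ccccc1`, continues the series at the same position. The change from compound 3 is ethyl in place of cyclopentyl on a nitrogen on an aromatic ring. Within the data shown here, the steps that bear on it are those just named, all of them within the scatter, and none of them points in a direction. On that basis compound 4 is expected to sit where compound 3 sits, with an expected step of no change at the digits printed from compound 3 to compound 4 (within the scatter), that is, none beyond the scatter. The estimate for compound 4 in this assay is 11000000 nM, with a range from 4000000 nM to 30000000 nM.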

Compound 4, inhibition constant: 91000000 nM
The estimate for compound 4 lay 8.3-fold (0.92 log units) below the measured number, and the stated range ends below it.
By their numbers in this assay, from the lowest: compounds 2, 3 and 1 (each within the scatter of the next); then compound 4.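

In this assay, among these compounds, the group on this nitrogen turns out to matter: ethyl gives the first steps beyond the scatter at this position, an 8.3-fold higher number from compound 3 to compound 4 (0.92 log units; beyond the scatter) and an 8.3-fold higher number from compound 2 to compound 4 (0.92 log units; beyond the scatter). The ring is not the whole story, since compound 1 also carries an open chain and is still separated from the ethyl compound, a 4.3-fold higher number from compound 1 to compound 4 (0.63 log units; beyond the scatter), a step that replaces hydroxymethyl with hydrogen on the chain. Nothing available explains why ethyl stands apart from the other three groups.

From the compounds shown here alone, it remains open whether propyl, which has no hydroxyl group, would stay with compound 4 or join compound 1. Nor do the compounds show where a bare amino group or a cyclohexyl group on this nitrogen would fall.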